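The compounds below may be only part of what the source reports. "The series", "measured", "known", "first", "only" and "open" are said of these compounds alone.

The measured compounds are:

compound 1, `CC[C@@H]1C(=O)N(C)c2cnc(Nc3ccc(S(=O)(=O)NC4CCCC4)cc3)nc2N1C1CCCC1` — 609 nM
compound 2, `CCC1C(=O)N(C)c2cnc(Nc3ccc(S(=O)(=O)NCC(C)C)cc3)nc2N1c1ccn(C)n1` — 5310 nM
compound 3, `CCCCNC(=O)c1ccc2c(ccn2-c2ncc3c(n2)N(c2ccn(C)n2)C(CC)C(=O)N3C)c1` — 4260 nM

In a functional assay on HeLa cells (Homo sapiens) for antiproliferative activity, read by CCK-8 assay, with a stated time of 72 h (on this read-out lower numbers stand for stronger inhibition of growth and higher numbers for weaker inhibition of growth), compound 1 gives 609 nM, the lowest of the three numbers. Compound 3 gives 4260 nM in this assay, a gap to compound 1 that lies beyond the usual scatter, and compound 2 gives 5310 nM, the furthest number from compound 1, also beyond the scatter. Compounds 2 and 3 differ from compound 1 in more than one place, so their values say only where each stands and not what any single change is worth.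

Compound 4, `CC[C@@H]1C(=O)N(C)c2cnc(Nc3ccc(S(=O)(=O)Nc4ccccc4)cc3)nc2N1C1CCCC1`, differs from compound 1 in one place: phenyl in place of cyclopentyl on a sulfonamide nitrogen. For the measured compounds named here, no pair among the measured compounds shows this change, so there is nothing in this assay to set its size or direction; the cyclopentyl of compound 1 and the phenyl of compound 4 are both carbon-only rings without donors or acceptors, and the rest of the molecule is unchanged. The expected step from compound 1 to compound 4 is therefore small, a 1.3-fold higher number from compound 1 to compound 4 (0.12 log units; within the scatter), and likely within the scatter. Compound 4 is estimated at 800 nM in this assay, with a range from 250 nM to 2500 nM.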

Compound 4, concentration for 50% growth inhibition: 5140 nM
Compound 4: middle estimate off by 6.4-fold (0.81 log units), on the low side, and the stated range ends below it.
By their numbers in this assay, from the lowest: compound 1; then compounds 3, 4 and 2 (each within the scatter of the next).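

For the compounds shown here, the change from cyclopentyl to phenyl on a sulfonamide nitrogen gives the first comparison in this set that isolates a single place, and in this assay it amounts to an 8.4-fold higher number from compound 1 to compound 4 (0.93 log units; beyond the scatter). This shows that the position does not treat all carbon-only rings alike: the two groups share the same count of hydrogen-bond donors and acceptors and carry no net charge, yet they are separated by a step beyond the scatter, with the entering ring being six-membered and aromatic and the leaving ring five-membered and non-aromatic. Nothing at hand accounts for this step, so the result stands as an observation without an explanation.

The compounds shown leave open whether the step goes with the larger ring or with the aromatic ring, a question that a cyclohexyl group on the same nitrogen, six-membered but non-aromatic, would help to settle. They also leave open whether a benzyl group, which holds the phenyl ring one carbon further out, or a phenyl ring bearing an amine would stay near compound 1 or near compound 4 in this assay.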